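The source may hold more compounds than are shown below. What is called first, only, known or untested is meant among the compounds shown, and "the series" means these compounds.

In a functional assay with Oryctolagus cuniculus as the target (a lower number here means a stronger inhibitor, a higher number a weaker inhibitor), compound 2 (`COc1ccc(-c2nc(CN(C)C)sc2-c2ccc(OC)cc2)cc1`) gives 96 nM as its reading, and compound 3 (`COc1ccc(-c2nc(CNC(=O)N3CCOCC3)sc2-c2ccc(OC)cc2)cc1`) gives 660 nM as the higher of the two true numbers. Compound 1 (`COc1ccc(-c2nc(/N=C(\N)[N+]3(C)CCCCC3)sc2-c2ccc(OC)cc2)cc1`) reads > 1000 nM in this test, which is a limit of the assay and not a number. Still unmeasured is compound 4 (`CNC(=O)NCc1nc(-c2ccc(OC)cc2)c(-c2ccc(OC)cc2)s1`), which differs from compound 3 by methylamino in place of morpholin-4-yl on a carbonyl carbon in one exchange: methylamino in place of morpholin-4-yl on a carbonyl carbon. Among the compounds with values here, no measured step swaps one group on that carbonyl carbon for another, so the evidence is indirect. The closest is the modest 6.9-fold higher number from compound 2 to compound 3 (0.84 log units; beyond the scatter) when the whole side group changes, while the large at least 10-fold lower number from compound 1 to compound 2 (1.01 log units; beyond the scatter) and the smaller at least 1.5-fold lower number from compound 1 to compound 3 (0.18 log units; that floor lies within the scatter) also replace that side group outright. Compound 4 keeps the carbonyl and its amino link from compound 3, so no change beyond the scatter is expected. The expected step is a 1.5-fold lower number from compound 3 to compound 4 (0.17 log units; within the scatter) in this assay and points only weakly downward. For compound 4 the estimated value is 450 nM with an expected range from 130 nM to 1300 nM in this measurement.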

Compound 4, half-maximal inhibitory concentration: 22 nM
Compound 4: the middle estimate sits 20-fold (1.31 log units) above what was measured; measured number outside the range, below it.
By their numbers in this assay, from the lowest: compound 4; then compound 2; then compound 3. At a limit, above all of these: compound 1.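

In this assay, within the data shown here, the group on the carbonyl carbon carries much of the outcome: methylamino in place of morpholin-4-yl gives a 30-fold lower number from compound 3 to compound 4 (1.48 log units; beyond the scatter), an exchange the earlier steps could not isolate because each replaced the whole side group. The carbonyl-and-amino link is therefore compatible with a low number, since (methylcarbamoyl)amino in place of dimethylamino gives a 4.4-fold lower number from compound 2 to compound 4 (0.64 log units; beyond the scatter). Compound 1 holds only a limit and not a number, so the reading an at least 45-fold lower number from compound 1 to compound 4 (1.65 log units; beyond the scatter) is a floor, set by this: the limit of > 1000 nM in this assay, at which 1 of the 4 values shown sits.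

Among these compounds, with only two groups compared on that carbonyl carbon, the smaller size of methylamino cannot be separated from the hydrogen-bond donor it brings. An ethylamino or a pyrrolidin-1-yl group there would be needed to tell these two apart.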